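Fluoro for methoxy on a pyridyl ether nicotinic ligand

The source may hold more compounds than are shown below. What is called first, only, known or untested is meant among the compounds shown, and "the series" means these compounds.

Of the compounds shown here, two have been measured in an assay on membranes from brain for binding affinity to Neuronal acetylcholine receptor; alpha4/beta2 (Rattus norvegicus); a higher number here means a weaker inhibitor, a lower number a stronger inhibitor. Compound 1 `CN1CCC[C@H]1COc1cncc(-c2cccc(N)c2)c1` gives 0.43 nM in this assay. Compound 2 `COc1ccc(-c2cncc(OC[C@@H]3CCCN3C)c2)cc1` gives 0.32 nM in this assay, and this number lies within the scatter of the number for compound 1, so the two cannot be told apart. Compound 3 `CN1CCC[C@H]1COc1cncc(-c2ccc(F)cc2)c1` has not yet been measured in this assay. It differs from compound 2 in one place: fluoro in place of methoxy on an aromatic carbon, the fluoro sitting para to a large group on a six-membered aromatic ring of carbon only. Among the measured compounds shown here, with no measured step of this kind available, the expectation can rest only on the shared core and the closeness of compound 1 and compound 2. Compound 3 is therefore expected to show a step of a 1.9-fold higher number from compound 2 to compound 3 (0.27 log units; within the scatter), a small shift toward a weaker number that would stay near the scatter. The estimate for compound 3 is 0.6 nM, with a range from 0.2 nM to 2 nM.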

Compound 3, inhibition constant: 0.11 nM
Estimate against measurement, compound 3: 5.5-fold (0.74 log units) above, outside the stated range (below it).
By their numbers in this assay, from the lowest: compound 3; then compounds 2 and 1 (each within the scatter of the next).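

Before this result no measured step existed at this place on the six-membered aromatic ring of carbon only. In this assay the change from methoxy to fluoro, para to a large group, gives a 2.9-fold lower number from compound 2 to compound 3 (0.46 log units; beyond the scatter) and so shows that this place still responds to its substituent at numbers already this low. Exchanging 3-aminophenyl for 4-fluorophenyl gives a 3.9-fold lower number from compound 1 to compound 3 (0.59 log units; beyond the scatter), which leaves compound 3 with the lowest number of the three, and no measurement at hand bears on why the fluoro compound has it.

Going by these compounds, it remains open whether the step belongs to the fluoro itself or to the loss of the methoxy. A plain hydrogen, a chloro or a nitrile at the same place would help separate the two readings.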